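The source may hold more compounds than are shown below. What is called first, only, known or untested is meant among the compounds shown, and "the series" means these compounds.

Compound 1, `CC(C)c1n[nH]c2c(NCc3ccc(-c4ccccn4)cc3)nc(SCC(O)C(F)(F)F)nc12`: 690 nM
Compound 2, `CC(C)c1n[nH]c2c(NCc3ccc(-c4ccccn4)cc3)nc(SC3CCCCC3O)nc12`: 636 nM
Compound 3, `CC(C)c1n[nH]c2c(NCc3ccc(-c4ccccn4)cc3)nc(SCC(O)CN3CCNCC3)nc12`: 332 nM

In a functional assay on HT cells (Homo sapiens) for antiproliferative activity, read by fluorescence, with a stated time of 72 h (on this read-out lower numbers stand for stronger inhibition of growth and higher numbers for weaker inhibition of growth), compound 3 gives the lowest of the three numbers; the two steps that lead to it are a 1.9-fold lower number from compound 2 to compound 3 (0.28 log units; within the scatter) and a 2.1-fold lower number from compound 1 to compound 3 (0.32 log units; beyond the scatter). Compound 4, `CC(=O)NCCSc1nc(NCc2ccc(-c3ccccn3)cc2)c2[nH]nc(C(C)C)c2n1`, differs from compound 3 as follows: acetamidomethyl in place of 1-hydroxy-2-(piperazin-1-yl)ethyl on a saturated chain carbon bound to a sulfur. Among the compounds with values here, two measured steps bear on this. The step of a 2.1-fold lower number from compound 1 to compound 3 (0.32 log units; beyond the scatter) is the only one that moved beyond the scatter, and it moved in the direction of the piperazine being present; the step of a 1.1-fold lower number from compound 1 to compound 2 (0.04 log units; within the scatter), which exchanged one small neutral side chain for another, stayed within the scatter. Removing the piperazine is therefore expected to give back part of that modest gain, so compound 4 is expected to read 600 nM, between 300 nM and 1200 nM, a step of a 1.8-fold higher number from compound 3 to compound 4 (0.26 log units; within the scatter).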

Compound 4, concentration for 50% growth inhibition: 71 nM
The estimate for compound 4 lay 8.5-fold (0.93 log units) above the measured number; measured number below the stated range.
By their numbers in this assay, from the lowest: compound 4; then compounds 3, 2 and 1 (each within the scatter of the next, the first and the last beyond it).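

In this assay, within the data shown here, the group on the sulfur matters far more than the earlier compounds suggested: 2-acetamidoethyl gives a 4.7-fold lower number from compound 3 to compound 4 (0.67 log units; beyond the scatter) and a 9.0-fold lower number from compound 2 to compound 4 (0.95 log units; beyond the scatter) and a 9.7-fold lower number from compound 1 to compound 4 (0.99 log units; beyond the scatter) against the three hydroxy-bearing side chains. The piperazine is thus not needed for a low number at this position, since a chain with no ring reads lower than the piperazine chain. Nothing measured here explains this gain.

From the compounds shown here alone, it remains open whether the carbonyl, the amide hydrogen or the chain length carries the gain, and how a primary amine, a carboxylic acid or a longer chain ending in acetamide would read on this sulfur.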